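This account rests on a few compounds, and the source may have more. Where it says the series, first, only, none or still open, it means among the compounds named here.

Among the compounds with values here, in a functional assay on Raji cells (Homo sapiens) for inhibition, read by MTT assay (on this read-out lower numbers stand for an effect already at smaller amounts and higher numbers for an effect only at larger amounts of compound), compound 2 (`CC(C)c1cc(=O)c2c(OCCCO)cc(OCc3ccc4ccccc4c3)cc2o1`) gives 100 nM, the lower of the two numbers known so far, while compound 1 (`Cc1cc(=O)c2c(OCCCO)cc(OCc3ccc4ccccc4c3)cc2o1`) gives 1000 nM. Compound 3 (`CC(C)c1cc(=O)c2c(OCc3ccccc3CO)cc(OCc3ccc4ccccc4c3)cc2o1`) carries 2-(hydroxymethyl)phenyl in place of 2-hydroxyethyl on a saturated chain carbon bound to an oxygen on an aromatic ring. Within the data shown here, the only measured step, a 10-fold lower number from compound 1 to compound 2 (1.00 log units; beyond the scatter), lies at another place and gives no direct guide to this change. The expected change in this assay is therefore a 1.5-fold higher number from compound 2 to compound 3 (0.18 log units; within the scatter), with none beyond the scatter expected. For compound 3 the estimated value is 150 nM, within an expected range of 40 nM to 600 nM.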

Compound 3, half-maximal effective concentration: > 100000 nM
Compound 3 was reported as a limit (the forecaster's own chance of this, stated with the estimate: 10%); middle value at least 660-fold (2.82 log units) away from the limit.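

In this assay, within the data shown here, the earlier compounds showed a step only at another place; here, 2-(hydroxymethyl)phenyl in place of 2-hydroxyethyl gives an at least 1000-fold higher number from compound 2 to compound 3 (3.00 log units; beyond the scatter). The read-out thus depends strongly on the group at this place, although both groups count the same hydrogen-bond donors and acceptors. The figure for compound 3 is a limit, not a number: the limit of > 100000 nM in this assay, at which 1 of the 3 values shown sits.

Whether the aromatic ring itself matters remains open, since only this one replacement is shown. A longer chain ending in hydroxyl, an amine or a carboxylic acid at this place could show how much change is tolerated.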